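Notes on amine-side variation in the sulfonyl tetralin series

A few compounds are considered here, and "the series" means these few. Any claim that something is new, unique, unknown or untested is made for them only; others in the source may bear on it.

Compound 1 `CN(C[C@@H]1CCCc2cc(S(=O)(=O)c3cccc(F)c3)ccc21)S(N)(=O)=O` gives 3.98 nM in an assay on isolated protein for displacement of a labelled ligand from 5-hydroxytryptamine receptor 6 (Homo sapiens); a higher number here means a weaker inhibitor, a lower number a stronger inhibitor. Within the data shown here, compound 2 `O=S(=O)(c1cccc(F)c1)c1ccc2c(c1)CCC[C@H]2CNCCO` gives 0.126 nM in this assay, the lower of the two numbers measured so far; its nearest neighbour is compound 1, and the single step between them, a 32-fold lower number from compound 1 to compound 2 (1.50 log units; beyond the scatter), is the only measured step. Compound 3 `CNCC(=O)NC[C@@H]1CCCc2cc(S(=O)(=O)c3cccc(F)c3)ccc21` has not been measured. It differs from compound 2 by ((methylamino)methyl)carbonyl in place of 2-hydroxyethyl on an amine nitrogen. Among the measured compounds shown here, the one step that bears on this change is the one from compound 1 to compound 2, in which a substituent on the same amine nitrogen was exchanged and the number moved by a large amount. Compound 3 keeps a nitrogen bearing a hydrogen-bond donor on that position, as compound 2 does, but carries a carbonyl there, as compound 1 carries a sulfonyl. Compound 3 is therefore expected to land between the two measured numbers, with an upward step a 7.9-fold higher number from compound 2 to compound 3 (0.90 log units; beyond the scatter) from compound 2. The estimate for compound 3 in this assay is 1 nM, within a range from 0.2 nM to 5 nM.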

Compound 3, inhibition constant: 0.159 nM
The estimate for compound 3 lay 6.3-fold (0.80 log units) above the measured number; measured number outside the range, below it.
By their numbers in this assay, from the lowest: compounds 2 and 3 (each within the scatter of the next); then compound 1.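

On the amine nitrogen whose other neighbour is a saturated chain carbon, ((methylamino)methyl)carbonyl in place of 2-hydroxyethyl gives a 1.3-fold higher number from compound 2 to compound 3 (0.10 log units; within the scatter) in this assay, so a carbonyl on this nitrogen is tolerated here, and the two groups cannot be told apart in this assay despite their different heavy-atom counts. The other new step, a 25-fold lower number from compound 1 to compound 3 (1.40 log units; beyond the scatter), is close in size to a 32-fold lower number from compound 1 to compound 2 (1.50 log units; beyond the scatter), so the large distance from compound 1 is not tied to 2-hydroxyethyl alone: two different groups on this nitrogen both stand well clear of methyl(sulfamoyl)amino. No measurement in hand explains why these groups match or why compound 1 stands apart.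

The compounds shown leave open whether the higher number of compound 1 goes with its sulfamoyl group or with the methyl on the same nitrogen, a question that the sulfamoylamino group without that methyl would address. They also leave open how far this position tolerates change, for example with a carboxylic acid in place of the methylamino of compound 3, or with a longer chain ahead of that amine.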